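Thiocarbamate variation on a piperidine carbamate series

The source may hold more compounds than are shown below. What is called first, only, known or untested is meant among the compounds shown, and "the series" means these compounds.

Measured so far:
compound 1 `Cc1nc(S(C)(=O)=O)ccc1Oc1ncnc(OC2CCN(C(=O)OC(C)(C)C#N)CC2)c1F` gives 97%
compound 2 `Cc1nc(S(C)(=O)=O)ccc1Oc1ncnc(OC2CCN(C(=O)SC(C)(C)C)CC2)c1F` gives 76%
compound 3 `Cc1nc(S(C)(=O)=O)ccc1Oc1ncnc(OC2CCN(C(=O)SC3CC3)CC2)c1F` gives 80%

In a functional assay on isolated protein for inhibition of Glucose-dependent insulinotropic receptor (Rattus norvegicus), read by HTRF and cAMP accumulation (on this read-out lower numbers stand for smaller maximal responses and higher numbers for larger maximal responses), compound 3 stands second highest of the three numbers. Its nearest neighbour is compound 2, and compound 3 and compound 2 lie within the scatter of each other, as shown by a number 4 percentage points higher from compound 2 to compound 3 (within the scatter). The furthest is compound 1, which sits clearly above: a number 17 percentage points lower from compound 1 to compound 3 (beyond the scatter).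

Compound 4 `Cc1nc(S(C)(=O)=O)ccc1Oc1ncnc(OC2CCN(C(=S)OC(C)C)CC2)c1F` has not been measured yet. It differs from compound 3 in one place: a group of 6 heavy atoms (4 carbon, 1 oxygen, 1 sulfur; no ring) in place of a group of 6 heavy atoms (4 carbon, 1 oxygen, 1 sulfur; one three-membered non-aromatic ring of carbon only), on an amine nitrogen in a ring.

Which measured steps bear on this? Neither directly. The steps of a number 21 percentage points lower from compound 1 to compound 2 (beyond the scatter) and a number 17 percentage points lower from compound 1 to compound 3 (beyond the scatter) both replace the 1-cyano-1-methylethoxy group on the carbonyl carbon and both lower the largest response modestly. The step of a number 4 percentage points higher from compound 2 to compound 3 (within the scatter), which swaps a tert-butyl for a cyclopropyl on the sulfur, stays within the scatter. The change to compound 4 keeps the same count of heavy atoms and acceptors on the ring nitrogen, so the closest analogy is the small step between compound 2 and compound 3 rather than the larger drops from compound 1.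

Compound 4 is therefore expected to show no step beyond the scatter in this assay, with a number 2 percentage points lower from compound 3 to compound 4 (within the scatter). Compound 4 is estimated at 78%, with a range from 62% to 94%.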

Compound 4, largest response reached (reported as efficacy), in percent of the reference or control that the assay uses: 47%
The estimate for compound 4 lay 31 percentage points above the measured number; the whole stated range lies above it.
By their numbers in this assay, from the lowest: compound 4; then compounds 2 and 3 (each within the scatter of the next); then compound 1.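

Among these compounds, the group on the amine nitrogen in a ring proved far more sensitive than the earlier compounds suggested: in this assay, a change that keeps 6 heavy atoms of the same elements, and the same counts of double bonds and hydrogen-bond acceptors, gave a number 33 percentage points lower from compound 3 to compound 4 (beyond the scatter). Matching counts therefore did not preserve the response here, and the sulfur's place in the group and the presence of the three-membered ring, which differ between these two compounds, may matter more than the size of the group. The other comparisons agree, with a number 29 percentage points lower from compound 2 to compound 4 (beyond the scatter) and a number 50 percentage points lower from compound 1 to compound 4 (beyond the scatter), which leaves compound 4 the lowest of the four, although nothing shown gives a measured reason for this fall.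

As far as these compounds go, what remains open is which part of the change carries the loss, as the sulfur's place and the three-membered ring change together in this step. A cyclopropyloxy group on the same thiocarbonyl, or an isopropylsulfanyl group on the carbonyl, would separate the two.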